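A few compounds are considered here, and "the series" means these few. Any claim that something is new, unique, unknown or untested is made for them only; others in the source may bear on it.

Three thiosemicarbazones have been measured in a functional assay on SGC-7901 cells (Homo sapiens) for antiproliferative activity, read by sulforhodamine B assay, with a stated time of 72 h; on this read-out lower numbers stand for stronger inhibition and higher numbers for weaker inhibition. Compound 1 `COc1ccccc1NC(=S)N/N=C/c1ccc2ccccc2n1` carries a 2-methoxyphenyl on the amide-type nitrogen whose other neighbour is the thiocarbonyl carbon. In this assay compound 1 returns a limit, > 100000 nM, and no number. That puts it at the limit of > 100000 nM in this assay, at which 1 of the 3 values shown sits, and leaves it as the one of the three without a measured value. Compound 2 `CN(C)C(=S)N/N=C/c1cc2cccnc2s1`, a dimethyl thiosemicarbazone on a different core, gives 21400 nM in this assay. Compound 3 `CN(C)C(=S)N/N=C/c1cnc2ccccc2n1`, also dimethyl but on another core, gives 170 nM in this assay, a lower number than that of compound 2. Among the measured compounds shown here, no pair among the three differs in a single place, so no step is measured. Compound 4 `COc1ccc(NC(=S)N/N=C/c2ccc3ccccc3n2)cc1` is next: 4-methoxyphenyl in place of 2-methoxyphenyl on an amide-type nitrogen; the two have the same atoms, joined differently. Because compound 1 gives the limit > 100000 nM, a result for compound 4 can only be read as a lowering or as another limit. The account expects the step of an at least 1.4-fold lower number from compound 1 to compound 4 (0.15 log units; that floor lies within the scatter) to stay within the scatter. Compound 4 is therefore estimated at 70000 nM, with a range from 15000 nM to 300000 nM.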

Compound 4, half-maximal inhibitory concentration: 89600 nM
For compound 4 the middle estimate is 1.3-fold (0.11 log units) below the measured one, within the range that was stated.
By their numbers in this assay, from the lowest: compound 3; then compound 2; then compound 4. At a limit, above all of these: compound 1.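

Among the compounds shown here, compound 1 remains a limit, > 100000 nM, and not a number, so compound 4 supplies the first measured value for an aryl group on the amide-type nitrogen whose other neighbour is the thiocarbonyl carbon. With 4-methoxyphenyl in place of 2-methoxyphenyl at that nitrogen, this assay gives an at least 1.1-fold lower number from compound 1 to compound 4 (0.04 log units; that floor lies within the scatter), so the change can be stated only as a floor, and that floor does not clear the usual scatter. The true size of the step stays unknown because one end of it is a limit: the limit of > 100000 nM in this assay, at which 1 of the 4 values shown sits.

From the compounds shown here alone, what a hydroxyl or a chlorine in place of the methoxy group on that phenyl would give in this assay stays open. So does how a plain phenyl, or the dimethyl group of compound 2 and compound 3, would read on the core of compound 1.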